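Swapping Fluoro for Chloro on the Shared Core

The source may hold more compounds than are shown below. What is called first, only, known or untested is meant among the compounds shown, and "the series" means these compounds.

Compound 1 `CC1CCN(c2c(S(=O)(=O)c3ccc(Cl)cc3)cnc3cc(Cl)ccc23)CC1` gives 91% in an assay on isolated protein for displacement of a labelled ligand from metabotropic glutamate receptor 5 (Homo sapiens), with a stated time of 60 min, tested at 1 uM; on this read-out lower numbers stand for less inhibition and higher numbers for more inhibition at the one concentration tested (going by the name of the read-out).
Compound 2 `CC1CCN(c2c(S(=O)(=O)c3ccc(F)cc3)cnc3cc(Cl)ccc23)CC1` gives 91% in this assay.
Compound 3 `CC1CCN(c2c(S(=O)(=O)c3ccc(F)c(F)c3)cnc3cc(F)ccc23)CC1` gives 94% in this assay.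

Compound 3 shows the highest of the three numbers, yet its gaps to compound 1 and compound 2 both lie within the scatter, so no order can be claimed. Compound 4 `CC1CCN(c2c(S(=O)(=O)c3ccc(F)c(F)c3)cnc3cc(Cl)ccc23)CC1` is not yet measured. Its difference from compound 3 is chloro in place of fluoro on an aromatic carbon. One measured step swaps the same two halogens, at another place: no change at the digits printed from compound 1 to compound 2 (within the scatter). That step moved nothing beyond the scatter, so the expected step of a number 2 percentage points lower from compound 3 to compound 4 (within the scatter) is also none beyond the scatter. Compound 4 is therefore estimated at 92%, expected between 84% and 98%.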

Compound 4, a percentage reported as inhibition, at one concentration (the size of the read-out at that concentration, not a potency): 90%
Compound 4: the middle estimate sits 2 percentage points above what was measured, within the range that was stated.
By their numbers in this assay, from the lowest: compounds 4, 1, 2 and 3 (each within the scatter of the next).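

Chloro in place of fluoro on this aromatic carbon of the shared core gives a number 4 percentage points lower from compound 3 to compound 4 (within the scatter). Fluoro in place of hydrogen on an aromatic carbon gives a number 1 percentage points lower from compound 2 to compound 4 (within the scatter), and 3,4-difluorophenyl in place of 4-chlorophenyl on the sulfonyl sulfur gives a number 1 percentage points lower from compound 1 to compound 4 (within the scatter). The chloro and fluoro swap thus reads alike at both places in this assay: the same change on two cores in this assay, no change at the digits printed (within the scatter) from compound 1 to compound 2 and a number 4 percentage points higher (within the scatter) from compound 4 to compound 3, 4 percentage points apart, within the scatter of two such steps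

With every step within the scatter at a single concentration, these numbers cannot tell the two halogens apart. On these data alone, whether an amine or a methoxy group on this carbon would move the number remains open.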